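Ethyl gives way to (tert-butyl)carbonyl on the ring nitrogen

The source may report more compounds than this note shows. Statements on the series, on what has been measured and on what is new or still open speak of the compounds shown alone.

Compound 1 `CNc1ncc2c(-c3ccc(N4CCNCC4)nc3)nn(Cc3cn(Cc4ccccc4)nn3)c2n1`: 400 nM
Compound 2 `CNc1ncc2c(-c3ccc(N4CCN(C)CC4)nc3)nn(Cc3cn(Cc4ccccc4)nn3)c2n1`: 380 nM
Compound 3 `CCN1CCN(c2ccc(-c3nn(Cc4cn(Cc5ccccc5)nn4)c4nc(NC)ncc34)cn2)CC1`: > 10000 nM

Three compounds sharing one core were tested in an assay for inhibition of tyrosine-protein kinase receptor UFO (Homo sapiens), read by 33P incorporation, in the presence of a further agent that is not named here; on this read-out higher numbers stand for weaker inhibition and lower numbers for stronger inhibition. Compound 1 gives 400 nM and compound 2 gives 380 nM; the step of a 1.1-fold lower number from compound 1 to compound 2 (0.02 log units; within the scatter) is small, so these two cannot be ordered. Compound 3 sits at a limit of this assay, > 10000 nM, and no number is known for it; this is the limit (the limit of > 10000 nM in this assay, at which 1 of the 3 values shown sits). The steps of an at least 25-fold higher number from compound 1 to compound 3 (1.39 log units; beyond the scatter) and an at least 26-fold higher number from compound 2 to compound 3 (1.42 log units; beyond the scatter) are both large, so compound 3 stands well apart from the other two.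

Compound 4 `CNc1ncc2c(-c3ccc(N4CCN(C(=O)C(C)(C)C)CC4)nc3)nn(Cc3cn(Cc4ccccc4)nn3)c2n1` has not been measured. It differs from compound 3 by (tert-butyl)carbonyl in place of ethyl on an amine nitrogen in a ring. Within the data shown here, no measured step shows this kind of change; the only steps bearing on it are those in which ethyl, in one case, or methyl, in the other, was added on the same ring nitrogen. Since compound 3 is known only as a limit, the direction of the expected step is uncertain, and the estimate is wide. Compound 4 is expected to give 2000 nM, between 300 nM and 10000 nM, a step of an at least 5.0-fold lower number from compound 3 to compound 4 (0.69 log units; beyond the scatter).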

Compound 4, half-maximal inhibitory concentration: 760 nM
Estimate against measurement, compound 4: 2.6-fold (0.42 log units) above, and the stated range covers the measured number.
By their numbers in this assay, from the lowest: compounds 2, 1 and 4 (each within the scatter of the next). At a limit, above all of these: compound 3.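

In this assay, putting (tert-butyl)carbonyl, with 6 heavy atoms, in place of ethyl, with 2, on the amine nitrogen in a ring brings a large change (an at least 13-fold lower number from compound 3 to compound 4 (1.11 log units; beyond the scatter)). The size of this step is only a bound, since the value of compound 3 is a limit and not a number: (the limit of > 10000 nM in this assay, at which 1 of the 4 values shown sits) Set against hydrogen (a 1.9-fold higher number from compound 1 to compound 4 (0.28 log units; within the scatter)) and methyl (a 2.0-fold higher number from compound 2 to compound 4 (0.30 log units; within the scatter)) on the same nitrogen, the new group stays within the scatter, so among these four compounds the number does not follow the size of the group, and compound 3 is the one that goes against any such reading.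

The compounds shown leave open whether the sharp rise belongs to ethyl alone or also to a longer chain such as propyl on this nitrogen. They also leave open whether the carbonyl or the tert-butyl part of the new group matters here, which an acetyl group or a neopentyl group on the same nitrogen would help to separate.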